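Swapping trifluoromethyl for bromo on a phenylurea

The source may report more compounds than this note shows. Statements on the series, on what has been measured and on what is new or still open speak of the compounds shown alone.

The measured compounds and their values:
Compound 1, `CCCCc1ccc(NC(=O)N[C@@H](C)c2ccccc2)cc1`, gives 60%.
Compound 2, `CCCCCCc1ccc(NC(=O)N[C@@H](C)c2ccccc2)cc1`, gives 99%.
Compound 3, `C[C@H](NC(=O)Nc1ccc(C(F)(F)F)cc1)c1ccccc1`, gives 94%.

These three share one urea core and differ only in the group on the aromatic carbon of the six-membered aromatic ring of carbon only. In an ADME assay on the whole organism with Oryza sativa as the target, tested at 10 uM (a lower number here means a stronger effect, a higher number a weaker effect of the compound at the concentration tested), compound 3 stands second highest of the three; compound 2 is nearest to it, a step within the scatter, and compound 1 is furthest, a number 34 percentage points higher from compound 1 to compound 3 (beyond the scatter).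

Compound 4, `C[C@H](NC(=O)Nc1ccc(Br)cc1)c1ccccc1`, carries bromo in place of trifluoromethyl on an aromatic carbon.

Within the data shown here, two measured steps touch the same position. Going from butyl to trifluoromethyl gave a number 34 percentage points higher from compound 1 to compound 3 (beyond the scatter), while going from hexyl to trifluoromethyl gave a number 5 percentage points lower from compound 2 to compound 3 (within the scatter). So a butyl group went with a low value, whereas hexyl and trifluoromethyl went with values near the top of the range. Bromo is a single heavy atom, unlike any group measured here, so no step shows its effect directly. On this thin basis compound 4 is expected to stay closer to compound 3 than to compound 1, with a modest downward step of about a number 14 percentage points lower from compound 3 to compound 4 (beyond the scatter). Compound 4 is therefore estimated at 80%, with a range from 45% to 100%.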

Compound 4, a percentage reported as activity, at one concentration (the size of the read-out at that concentration, not a potency): 96%
Compound 4: middle estimate off by 16 percentage points, on the low side; measured number inside the range.
By their numbers in this assay, from the lowest: compound 1; then compounds 3, 4 and 2 (each within the scatter of the next).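

In this assay, putting bromo, with 1 heavy atom, in place of trifluoromethyl, with 4 heavy atoms, gives a number 2 percentage points higher from compound 3 to compound 4 (within the scatter) and so leaves the read-out unchanged within the usual scatter, and the comparison with the longer chain gives a number 3 percentage points lower from compound 2 to compound 4 (within the scatter) with the same reading. Bromo, trifluoromethyl and hexyl therefore sit level at this place on the aromatic ring, although they share little in shape or composition, and butyl is now the one group of the four that stands apart, with a number 36 percentage points higher from compound 1 to compound 4 (beyond the scatter) as a large step. Nothing measured here explains why butyl alone differs.

On these data alone, it remains open whether the butyl result is an isolated exception or part of a trend along the chain, which a propyl or pentyl group at the same place could help to settle. As far as these compounds go, it is equally open whether the level seen with bromo extends to groups of a different kind on the aromatic carbon, such as an amine or a carboxylic acid.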